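Series notes: iodo for furan-2-yl at the aromatic carbon

The source may report more compounds than this note shows. Statements on the series, on what has been measured and on what is new or still open speak of the compounds shown alone.

Compound 2 `O=C1Nc2ccc(-c3ccco3)cc2/C1=C/c1cc(Cl)c(O)c(Cl)c1` stands highest of the two numbers measured in an assay on HeLa cells for inhibition of Kinesin-like protein KIF15 (Homo sapiens), read by microscopy, with stated times of 2 s and 20 s, tested at 750 nM (on this read-out lower numbers stand for less inhibition and higher numbers for more inhibition at the one concentration tested (going by the name of the read-out)), where compound 2 gives 33%. Compound 1 `CN(C)C(=O)c1ccc2c(c1)/C(=C/c1cc(Cl)c(O)c(Cl)c1)C(=O)N2` gives 15.3% in this assay. Among the measured compounds shown here, the one measured step, a number 17.7 percentage points higher from compound 1 to compound 2 (beyond the scatter), brought furan-2-yl in place of dimethylcarbamoyl on an aromatic carbon. Compound 3 `O=C1Nc2ccc(I)cc2/C1=C/c1cc(Cl)c(O)c(Cl)c1` is not yet measured; it differs from compound 2 by iodo in place of furan-2-yl on an aromatic carbon. For the measured compounds named here, no measured step exchanges furan-2-yl for iodo, so the only guide is that the same aromatic carbon has already borne two different groups with a modest shift between them. A small downward step, a number 8 percentage points lower from compound 2 to compound 3 (within the scatter), is expected, because compound 2 bearing furan-2-yl gave 33% while compound 1 with a different group there gave 15.3%, and the range between the two is wide. For compound 3 the estimate in this assay is 25%, within 5% to 50%.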

Compound 3, a percentage reported as inhibition, at one concentration (the size of the read-out at that concentration, not a potency): 15%
Estimate against measurement, compound 3: 10 percentage points above; measured number inside the range.
By their numbers in this assay, from the lowest: compounds 3 and 1 (each within the scatter of the next); then compound 2.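

In this assay, iodo in place of furan-2-yl on an aromatic carbon gives a number 18 percentage points lower from compound 2 to compound 3 (beyond the scatter), so the number for compound 2 does not hold when furan-2-yl is replaced by this single-atom group either. Iodo in place of dimethylcarbamoyl gives a number 0.3 percentage points lower from compound 1 to compound 3 (within the scatter), which leaves furan-2-yl as the only one of the three groups at this position that stands apart, while the other two cannot be told apart in this assay. Nothing available here gives a reason for the difference between furan-2-yl and the other two groups.

On these data alone, it remains open whether another ring at this aromatic carbon, such as thiophene or phenyl, would read like compound 2, or whether a small amine would read like compound 3. As far as these compounds go, with one concentration per compound, the potency of all three compounds also remains open.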